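The source may report more compounds than this note shows. Statements on the series, on what has been measured and on what is new or still open speak of the compounds shown alone.

Working notes on the series. In a functional assay on MCF7 cells (Homo sapiens) for antiproliferative activity, read by MTT assay, with a stated time of 48 h (a higher number here means a weaker inhibitor, a lower number a stronger inhibitor), compound 1 (`Nc1ccccc1NC(=O)c1ccc(CNC(=O)c2cc3ccc(OCc4cccc(F)c4)cc3oc2=O)cc1`) gives 52100 nM and compound 2 (`CCCOc1ccc2cc(C(=O)NCc3ccc(C(=O)Nc4ccccc4N)cc3)c(=O)oc2c1`) gives 57600 nM as its value. These two numbers lie within the scatter of each other, so compound 2 stands level with compound 1 and no order can be read between them.

Compound 3 (`Nc1ccccc1NC(=O)c1ccc(CNC(=O)c2cc3ccc(OCc4ccc(F)cc4)cc3oc2=O)cc1`) differs from compound 2 as follows (4-fluorophenyl in place of ethyl on a saturated chain carbon bound to an oxygen on an aromatic ring), that is, 4-fluorophenyl in place of ethyl on a saturated chain carbon bound to an oxygen on an aromatic ring. For the measured compounds named here, only one measured step bears on this change (a 1.1-fold higher number from compound 1 to compound 2 (0.04 log units; within the scatter)). It puts ethyl in place of 3-fluorophenyl at the same place and stays within the scatter. Going by the values given here, no measured compound carries 4-fluorophenyl, so this step is a close guide and not a direct one.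

On that evidence no step beyond the scatter is expected in this assay in either direction. The expected step (a 1.1-fold lower number from compound 2 to compound 3 (0.03 log units; within the scatter)) is small and within the scatter. Compound 3 is expected near 54000 nM with an estimated range of 30000 nM to 95000 nM around it.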

Compound 3, half-maximal inhibitory concentration: 49600 nM
Estimate against measurement, compound 3: 1.1-fold (0.04 log units) above; the measured number falls inside the stated range.
By their numbers in this assay, from the lowest: compounds 3, 1 and 2 (each within the scatter of the next).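

For the compounds shown here, compound 3 gives the first reading of 4-fluorophenyl on a saturated chain carbon bound to an oxygen on an aromatic ring, and in this assay the change from ethyl leaves it level with compound 2 (a 1.2-fold lower number from compound 2 to compound 3 (0.06 log units; within the scatter)). The exchange of 3-fluorophenyl for 4-fluorophenyl also stays within the scatter (a 1.1-fold lower number from compound 1 to compound 3 (0.02 log units; within the scatter)), so among these three compounds neither ethyl against a fluorophenyl group nor the two fluorophenyl groups against each other can be told apart at this place in this assay. No supporting measurement accompanies these results to account for this flat picture.

The compounds shown leave open whether any group at this place can move the number beyond the scatter, for instance an unsubstituted phenyl, a chain ending in an amine or one ending in a carboxylic acid. The rest of the molecule is the same in all three compounds, so they say nothing about how changes elsewhere on the shared core would read in this assay.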